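The source may report more compounds than this note shows. Statements on the series, on what has been measured and on what is new or still open speak of the compounds shown alone.

In an assay on isolated protein for inhibition of 3-oxo-5-alpha-steroid 4-dehydrogenase 2 (Homo sapiens) (a higher number here means a weaker inhibitor, a lower number a stronger inhibitor), compound 1 `O=C(O)c1ccc(C=C2CCN(C(=O)C(C3CCCCC3)C3CCCCC3)CC2)cc1` gives 60 nM, compound 2 `O=C(O)Cc1ccc(C=C2CCN(C(=O)C(C3CCCCC3)C3CCCCC3)CC2)cc1` gives 6 nM and compound 3 `O=C(O)c1ccc(C=C2CCN(C(=O)C(C3CCCCC3)C3CCCCC3)CC2)c(F)c1` gives 11 nM. Compound 3 holds the second highest of the three numbers: a 1.8-fold higher number from compound 2 to compound 3 (0.26 log units; within the scatter), whereas a 5.5-fold lower number from compound 1 to compound 3 (0.74 log units; beyond the scatter). Compound 4 `COc1cc(C(=O)O)ccc1C=C1CCN(C(=O)C(C2CCCCC2)C2CCCCC2)CC1` differs from compound 3 by methoxy in place of fluoro on an aromatic carbon. Within the data shown here, the one measured step at that place is the fluoro entry, a 5.5-fold lower number from compound 1 to compound 3 (0.74 log units; beyond the scatter); no methoxy step exists, and the other step, a 10-fold lower number from compound 1 to compound 2 (1.00 log units; beyond the scatter), concerns the carboxy group instead. Since the fluoro step gives no direct guide for methoxy, a number near that of compound 3 or somewhat higher is expected: a 1.6-fold higher number from compound 3 to compound 4 (0.21 log units; within the scatter). Compound 4 is therefore estimated at 18 nM, with a range from 5 nM to 60 nM.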

Compound 4, half-maximal inhibitory concentration: 130 nM
Estimate against measurement, compound 4: 7.2-fold (0.86 log units) below, outside the stated range (above it).
By their numbers in this assay, from the lowest: compounds 2 and 3 (each within the scatter of the next); then compound 1; then compound 4.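

At this position, on an aromatic carbon ortho to a large group, the outcome depends on the substituent: fluoro lowers the number, whereas methoxy in place of hydrogen gives a 2.2-fold higher number from compound 1 to compound 4 (0.34 log units; beyond the scatter). Methoxy in place of fluoro gives a 12-fold higher number from compound 3 to compound 4 (1.07 log units; beyond the scatter), so substitution here does not help in itself. The 4-carboxy-2-methoxyphenyl group also falls well short of 4-(carboxymethyl)phenyl, with a 22-fold higher number from compound 2 to compound 4 (1.34 log units; beyond the scatter).

Nothing available accounts for this reversal. On these data alone, whether chloro or hydroxy at this position would track fluoro or methoxy remains open, as does the effect of either group alongside the carboxymethyl chain.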